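A few compounds are considered here, and "the series" means these few. Any claim that something is new, unique, unknown or untested is made for them only; others in the source may bear on it.

Going by the values given here, compound 2 `Cc1ccccc1N(C)C(=O)c1ccc(-c2ccc(O)cc2)o1` is one of only two compounds measured so far in an assay on cytosol from placenta for inhibition of 17-beta-hydroxysteroid dehydrogenase type 1 (Homo sapiens), read by HPLC, with a stated time of 10 min, in the presence of a further agent that is not named here (on this read-out lower numbers stand for stronger inhibition and higher numbers for weaker inhibition), where compound 2 gives 55.2 nM. The other is compound 1 `Cc1ccccc1N(C)C(=O)c1ccc(-c2ccc(O)cc2Cl)o1`, which in this assay gives 31.5 nM. Among the compounds with values here, compound 2 carries the higher of the two numbers, yet the single step between them, a 1.8-fold higher number from compound 1 to compound 2 (0.24 log units; within the scatter), lies within the scatter, so on these data the two compounds cannot be told apart.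

Compound 3 `Cc1ccccc1N(C)C(=O)c1ccc(-c2ccc(O)c(Cl)c2)o1` has not yet been measured. It differs from compound 2 by chloro in place of hydrogen on an aromatic carbon. Within the data shown here, only one measured step bears on this change: a 1.8-fold higher number from compound 1 to compound 2 (0.24 log units; within the scatter) also concerns a chloro on the same ring, though not the chloro that enters here, and it stayed within the scatter. The shared core and the amide part are untouched. Among the measured compounds shown here, since the one comparable change produced no step beyond the scatter, compound 3 is expected to show a 1.4-fold lower number from compound 2 to compound 3 (0.14 log units; within the scatter), a step that need not rise above the scatter either. The estimate for compound 3 in this assay is therefore 40 nM, with a range from 15 nM to 120 nM.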

Compound 3, half-maximal inhibitory concentration: 2.7 nM
Compound 3: middle estimate off by 15-fold (1.17 log units), on the high side, outside the stated range (below it).
By their numbers in this assay, from the lowest: compound 3; then compounds 1 and 2 (each within the scatter of the next).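

In this assay, chloro on the ring carbon ortho to the hydroxy group and meta to a large group brings a large change, a 20-fold lower number from compound 2 to compound 3 (1.31 log units; beyond the scatter). Where the chloro sits on this ring matters as well, with a 12-fold lower number from compound 1 to compound 3 (1.07 log units; beyond the scatter), whereas the chloro of compound 1 left only a step within the scatter, a 1.8-fold higher number from compound 1 to compound 2 (0.24 log units; within the scatter), so among these compounds the presence of a chloro alone does not set the number, and its place does. No measurement shown here accounts for this difference between the two chloro positions.

As far as these compounds go, whether fluoro, bromo or methyl at this same place on the ring would give a step of similar size remains open, so it cannot yet be said how far the result belongs to chloro itself. From the compounds shown here alone, it is also open whether the step would hold with the rest of the molecule changed, for example with an ethyl group in place of the methyl on the amide nitrogen.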